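Notes on the step from compound 2 to compound 3

This account rests on a few compounds, and the source may have more. Where it says the series, first, only, none or still open, it means among the compounds named here.

Compound 1 `Cc1c2c(n3c1CCN(C(=O)CN)C[C@@H](C)[C@H](C)Nc1cc-3ccc1C(N)=O)CC(C)(C)CC2=O`: > 0.5 h, a limit of the assay
Compound 2 `Cc1c2c(n3c1CCN(C(=O)C(C)(C)N)C[C@@H](C)[C@H](C)Nc1cc-3ccc1C(N)=O)CC(C)(C)CC2=O`: 0.417 h

Going by the values given here, compound 2 gives the only actual number in an in vitro ADME assay on microsomes (Homo sapiens) for metabolic stability (a lower number here means that the compound disappears faster, a higher number that the compound lasts longer), 0.417 h. Compound 1 is reported only as a limit: the limit of > 0.5 h in this assay, at which 1 of the 2 values shown sits. Compound 3 `Cc1c2c(n3c1CCN(C(=O)C1(N)CCCC1)C[C@@H](C)[C@H](C)Nc1cc-3ccc1C(N)=O)CC(C)(C)CC2=O` carries 1-aminocyclopentyl in place of 1-amino-1-methylethyl on a carbonyl carbon. Among the compounds with values here, the one measured step bearing on this, an at least 1.1-fold lower number from compound 1 to compound 2 (0.07 log units; that floor lies within the scatter), also changed the group on that carbonyl carbon, and it gives no ground for a large move. A slight drift in the same direction is expected, no clear step beyond the scatter: the expected step is a 1.2-fold lower number from compound 2 to compound 3 (0.08 log units; within the scatter). For compound 3 the estimated half-life is 0.35 h, with an expected range of 0.18 h to 0.55 h.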

Compound 3, half-life: 0.0667 h
The estimate for compound 3 lay 5.2-fold (0.72 log units) above the measured number; the whole stated range lies above it.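

In this assay, 1-aminocyclopentyl in place of 1-amino-1-methylethyl gives a 6.3-fold lower number from compound 2 to compound 3 (0.80 log units; beyond the scatter), so the group on this carbonyl carbon can move the half-life beyond the scatter, which the earlier step, with its floor within the scatter, did not show. Against aminomethyl, the same group gives an at least 7.4-fold lower number from compound 1 to compound 3 (0.87 log units; beyond the scatter). Compound 1 is a limit, not a number: the limit of > 0.5 h in this assay, at which 1 of the 3 values shown sits.

Open, on these data alone, is whether the ring itself or the larger group size goes with the lower number. Also open, as far as these compounds go, is whether 1-aminocyclobutyl or 1-aminocyclohexyl would read closer to compound 2 or to compound 3 in this assay.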